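This account rests on a few compounds, and the source may have more. Where it says the series, first, only, none or still open, it means among the compounds named here.

In a functional assay on A549 cells (Homo sapiens) for cytotoxicity, read by MTT assay, with a stated time of 72 h (on this read-out higher numbers stand for weaker inhibition and lower numbers for stronger inhibition), compound 1 `O=C(/C=C/c1ccc([N+](=O)[O-])cc1)Nc1cc2c(Nc3ccc(F)c(Cl)c3)ncnc2cc1O[C@H]1CCOC1` gives 12000 nM and compound 2 `COc1ccc(OC)c(/C=C/C(=O)Nc2cc3c(Nc4ccc(F)c(Cl)c4)ncnc3cc2OC)c1` gives 11200 nM so far, and these two values lie within the usual scatter of each other. Compound 2 therefore stands level with compound 1, and neither can be called the stronger of the pair. Compound 3 `COc1cc2ncnc(Nc3ccc(F)c(Cl)c3)c2cc1NC(=O)/C=C/c1ccccc1[N+](=O)[O-]` has not been measured yet. It differs from compound 2 by a single change (2-nitrophenyl in place of 2,5-dimethoxyphenyl on a double-bonded chain carbon bound to a double-bonded chain carbon) that puts 2-nitrophenyl in place of 2,5-dimethoxyphenyl on a double-bonded chain carbon bound to a double-bonded chain carbon. Among the measured compounds shown here, no measured pair shows what such a swap does, so in this assay the expectation is no shift beyond the scatter in either direction. The step of a 1.0-fold lower number from compound 2 to compound 3 (0.01 log units; within the scatter) is expected to stay that small. The estimate for compound 3 is 11000 nM in the middle, with an expected range from 4000 nM to 30000 nM at its upper end.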

Compound 3, half-maximal inhibitory concentration: 33300 nM
For compound 3 the middle estimate is 3.0-fold (0.48 log units) below the measured one; the whole stated range lies below it.
By their numbers in this assay, from the lowest: compounds 2 and 1 (each within the scatter of the next); then compound 3.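

In this assay, the group on a double-bonded chain carbon bound to a double-bonded chain carbon can change the result: 2-nitrophenyl in place of 2,5-dimethoxyphenyl gives a 3.0-fold higher number from compound 2 to compound 3 (0.47 log units; beyond the scatter), a modest step towards weaker inhibition. Both groups carry one six-membered aromatic ring of carbon only, with equal counts of hydrogen-bond donors and acceptors and no net charge, so these counted features do not separate them. No supporting measurement is available to explain the step.

This single pair cannot show whether the step follows from gaining the nitro group or from losing the two methoxy groups. A plain phenyl, or an amine in place of the nitro group, at this same place would help to separate those two readings.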